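From hydroxy to methoxy in compound 3

This account rests on a few compounds, and the source may have more. Where it says the series, first, only, none or still open, it means among the compounds named here.

Measured in a functional assay on OVCAR-3 cells (Homo sapiens) for inhibition, read by sulforhodamine B assay, with a stated time of 48 h (a higher number here means that more compound is tolerated, a lower number that less compound is tolerated), so far:
- Compound 1 `O=C(Nc1cccc(-n2cc(-c3ccncc3)c(-c3ccc(Cl)c(O)c3)n2)c1)Nc1cccc(C(F)(F)F)c1` gives > 32500 nM as a limit.
- Compound 2 `COc1cc(-c2nn(-c3cccc(NC(=O)c4cccc(C(F)(F)F)c4)c3)cc2-c2ccncc2)ccc1Cl` gives > 50000 nM as a limit.

Going by the values given here, compound 1 therefore has no exact number in this assay to stand on, and the only other value is also a limit. Compound 3 `COc1cc(-c2nn(-c3cccc(NC(=O)Nc4cccc(C(F)(F)F)c4)c3)cc2-c2ccncc2)ccc1Cl` differs from compound 1 by methyl in place of hydrogen on an oxygen on an aromatic ring with methyl in place of hydrogen on an oxygen on an aromatic ring, which turns 4-chloro-3-hydroxyphenyl into 4-chloro-3-methoxyphenyl. Among the compounds with values here, no measured pair shows this change. Compound 2 also carries 4-chloro-3-methoxyphenyl and stands at > 50000 nM as a limit. On that basis, no change beyond the usual scatter is expected in this assay, and a further limit is the likeliest report. The expected size is a step that the limit leaves unreadable from compound 1 to compound 3 in this estimate. Compound 3 is estimated at 45000 nM with an expected range from 15000 nM to 100000 nM in this assay.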

Compound 3, concentration lethal to 50% of the cells: 24700 nM
Estimate against measurement, compound 3: 1.8-fold (0.26 log units) above, within the range that was stated.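

In this assay compound 3 gives 24700 nM, the first exact number among the compounds shown. Hydroxy to methoxy on the aromatic ring gives an at least 1.3-fold lower number from compound 1 to compound 3 (0.11 log units; that floor lies within the scatter), and (3-(trifluoromethyl)phenyl)amino in place of 3-(trifluoromethyl)phenyl on a carbonyl carbon gives an at least 2.0-fold lower number from compound 2 to compound 3 (0.30 log units; that floor lies within the scatter). Both figures are only floors that lie within the scatter, so neither change is shown to matter, and the true size of the hydroxy to methoxy step stays unknown because that step starts from a limit: the limit of > 32500 nM in this assay, at which 1 of the 3 values shown sits.

From the compounds shown here alone, it remains open how a longer chain on that oxygen, such as ethoxy, or an amine in place of the hydroxy would read in this assay. An exact number for compound 1 would be needed to give the hydroxy to methoxy step a real size.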